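Swapping the amide aryl toward a pyridine in a dopamine series

This account rests on a few compounds, and the source may have more. Where it says the series, first, only, none or still open, it means among the compounds named here.

Measured compounds:
Compound 1 `O=C(CN1CCN(c2ccccn2)CC1)Nc1cccnc1` gives 47.3% in a functional assay on cells for agonist activity at D(4) dopamine receptor (Homo sapiens), read by TR-FRET and cAMP accumulation, with a stated time of 30 min; on this read-out lower numbers stand for smaller maximal responses and higher numbers for larger maximal responses.
Compound 2 `Cc1cccc(NC(=O)CN2CCN(c3ccc(Cl)cn3)CC2)c1` is reported in this assay as "not active" (no number reported), with no number.
Compound 3 `CCc1cccc(NC(=O)CN2CCN(c3ccc(Cl)cn3)CC2)c1` is likewise reported in this assay as "not active" (no number reported), with no number.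

Compound 3 therefore stands without a value of its own: it is one of two entries in the set for which this assay returns no number, and the only numbered result in the set belongs to compound 1. Compound 4 `O=C(CN1CCN(c2ccc(Cl)cn2)CC1)Nc1cccnc1` is not yet measured. It differs from compound 3 by pyridin-3-yl in place of 3-ethylphenyl on an amide-type nitrogen. Within the data shown here, no measured pair shows this particular change, so the size of the step in this assay cannot be read from the data; a shift toward a measurable maximal response seems plausible, since compound 1, which carries the same pyridin-3-yl amide, gives 47.3%, while both compounds bearing a substituted phenyl on the amide nitrogen returned no number. Compound 4 is therefore expected to give roughly 40%, with a range from 15% to 65%, though a report of no activity remains a real possibility.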

Compound 4, largest response reached (Emax), in percent of the reference or control that the assay uses: "not active" (no number reported)
The entry for compound 4 holds no number; the estimate stays without a comparison.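

Compound 3 and compound 4 are both reported as not active, so no step can be read from this pair. No other evidence bears on this result. The compounds shown leave open what separates compound 4 from compound 1, the only compound here with a number.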